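Sulfonyl in Place of Carboxamide on a Shared Core

The source may report more compounds than this note shows. Statements on the series, on what has been measured and on what is new or still open speak of the compounds shown alone.

Compound 1 `Cn1c(=O)c(C(=O)Nc2ccc(F)cc2)cc2cnc(Nc3ccc4[nH]ccc4c3)nc21` is examined in a functional assay on DU-145 cells (Homo sapiens) for inhibition, read by trypan blue exclusion, with a stated time of 72 h (a higher number here means a weaker inhibitor, a lower number a stronger inhibitor), where compound 1 gives 5000 nM. That number is level with compound 2 `CN1CCN(c2ccc(Nc3ncc4cc(S(=O)(=O)c5ccc(F)cc5F)c(=O)n(C)c4n3)cc2)CC1`, which in this assay gives 5000 nM; together these two are the lowest of the three values. Compound 3 `Cn1c(=O)c(S(=O)(=O)c2ccc(F)cc2F)cc2cnc(NCc3ccc4[nH]ccc4c3)nc21` stands furthest away, giving 100000 nM in this assay, a number beyond the scatter above the other two. Compound 4 `Cn1c(=O)c(S(=O)(=O)c2ccc(N)cc2F)cc2cnc(Nc3ccc4[nH]ccc4c3)nc21` has not yet been measured. It differs from compound 1 in one place: (4-amino-2-fluorophenyl)sulfonyl in place of (4-fluorophenyl)carbamoyl on an aromatic carbon. Compound 2 also bears a sulfonyl group and gives 5000 nM, so no step beyond the scatter is expected from this change. The expected step of no change at the digits printed from compound 1 to compound 4 (within the scatter) is small. Compound 4 is therefore estimated at 5000 nM in this assay, with a range from 1000 nM to 30000 nM.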

Compound 4, half-maximal inhibitory concentration: 8000 nM
For compound 4 the middle estimate is 1.6-fold (0.20 log units) below the measured one, and the stated range covers the measured number.
By their numbers in this assay, from the lowest: compounds 1, 2 and 4 (each within the scatter of the next); then compound 3.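

For the compounds shown here, at this aromatic carbon, the first comparison that changes one place only shows that (4-amino-2-fluorophenyl)sulfonyl can replace (4-fluorophenyl)carbamoyl in this assay with a 1.6-fold higher number from compound 1 to compound 4 (0.20 log units; within the scatter), so the two groups cannot be told apart here. The earlier compounds shown here each differed from compound 1 in more than one place and could not show this. Nothing measured here explains the result. The compounds shown leave open how a carboxylic acid or a plain phenylsulfonyl at this carbon would stand in this assay. They also do not separate the contribution of the sulfonyl link from that of the amine on its ring.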